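A methoxy group in place of chloro on compound 1

The source may hold more compounds than are shown below. What is called first, only, known or untested is meant among the compounds shown, and "the series" means these compounds.

Going by the values given here, in a functional assay on the whole organism with Mus musculus as the target (on this read-out lower numbers stand for an effect already at smaller amounts and higher numbers for an effect only at larger amounts of compound), compound 1 `Cn1nc(-c2ccc(Cl)cc2)n(C)c1=S` gives 1.34 mg/kg, the lowest of the two numbers measured so far. Among the compounds with values here, its nearest neighbour is compound 2 `Cn1nc(-c2ccc(Cl)c(Cl)c2)n(C)c1=S`, which in this assay gives 29 mg/kg; the step of a 22-fold higher number from compound 1 to compound 2 (1.34 log units; beyond the scatter) is the only measured step, and it shows that a single change on the six-membered aromatic ring can move the number far beyond the scatter. Compound 3 `COc1ccc(-c2nn(C)c(=S)n2C)cc1` differs from compound 1 in another way: methoxy in place of chloro on an aromatic carbon. No measured step swaps chloro for methoxy, so the direction of this change is not shown by the data. Because the step of a 22-fold higher number from compound 1 to compound 2 (1.34 log units; beyond the scatter) points to a ring region where the number readily grows, a moderate rise beyond the scatter is expected for compound 3, with a wide range. Compound 3 is estimated at 4 mg/kg, between 1 mg/kg and 16 mg/kg, which would mean an expected step of a 3.0-fold higher number from compound 1 to compound 3 (0.47 log units; beyond the scatter).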

Compound 3, dose for half-maximal effect: > 25 mg/kg
Compound 3 was reported as a limit; the forecaster's own chance of this, stated with the estimate: 10%; middle value at least 6.2-fold (0.79 log units) away from the limit.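

In this assay, methoxy in place of chloro on the aromatic carbon para to a group of 8 heavy atoms gives an at least 18-fold higher number from compound 1 to compound 3 (1.27 log units; beyond the scatter). The earlier compounds had shown only that adding a chloro to the ring can move the number far, whereas this step shows that the chloro already present in compound 1 cannot be exchanged for methoxy without a large change. For compound 3 the reading is a limit and not a number: the limit of > 25 mg/kg in this assay, at which 1 of the 3 values shown sits.

The compounds shown leave open whether this step is particular to methoxy or would also follow from fluoro, methyl or an amine on the same carbon. They also leave open how far the number of compound 3 lies past its limit.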